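Replacing acetoxy with hydrogen on compound 2

The source may hold more compounds than are shown below. What is called first, only, known or untested is meant among the compounds shown, and "the series" means these compounds.

In a physicochemical assay for lipophilicity (on this read-out lower numbers stand for lower lipophilicity and higher numbers for higher lipophilicity), compound 2 `CC(=O)OCOC(=O)c1ccccc1OC(C)=O` stands highest of the two measured compounds at 1.42 against the other, while compound 1 `CCNC(=O)COC(=O)c1ccccc1OC(C)=O` gives 0.9 as the lower number. For the measured compounds named here, compound 3 `COC(=O)c1ccccc1OC(C)=O` differs from compound 2 by hydrogen in place of acetoxy on a saturated chain carbon bound to an oxygen next to a carbonyl group as its single change: hydrogen in place of acetoxy on a saturated chain carbon bound to an oxygen next to a carbonyl group. Going by the values given here, the only measured step at that place is a number 0.52 log units higher from compound 1 to compound 2 (beyond the scatter) with acetoxy in place of ethylcarbamoyl, a modest move and a different exchange, so it offers loose guidance only. The expected change is a number 0.08 log units higher from compound 2 to compound 3 (within the scatter) and no shift beyond the scatter is expected in this assay here. Compound 3 is estimated at 1.5 within 1.1 to 1.9 as the expected range.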

Compound 3, partition coefficient: 1.46
For compound 3 the middle estimate is 0.04 log units above the measured one; measured number inside the range.
By their numbers in this assay, from the lowest: compound 1; then compounds 2 and 3 (each within the scatter of the next).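

In this assay the exchange of acetoxy for hydrogen reads a number 0.04 log units higher from compound 2 to compound 3 (within the scatter) and so does not separate these two groups on this saturated chain carbon. For the compounds shown here, the exchange of ethylcarbamoyl for hydrogen reads a number 0.56 log units higher from compound 1 to compound 3 (beyond the scatter) and so leaves ethylcarbamoyl as the only one of the three groups that stands apart at this place. No available evidence accounts for this pattern. Open, going by these compounds, is where an amine, a carboxylic acid or a longer chain at this place would fall relative to hydrogen and ethylcarbamoyl.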